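Amino-chloropyridinyl ether replacing the glycolamide side chain

The source may hold more compounds than are shown below. What is called first, only, known or untested is meant among the compounds shown, and "the series" means these compounds.

Compound 2 `O=C(CO)Nc1cc(Oc2ccc(Nc3nccc4[nH]cc(-c5ccc(F)cc5)c(=O)c34)cc2F)ccn1` is the lower of the two values shown in a functional assay on HT-29 cells (Homo sapiens) for antiproliferative activity, read by MTT assay, with a stated time of 72 h, tested at 10 uM (a higher number here means more inhibition at the concentration tested (going by the name of the read-out), a lower number less inhibition), where compound 2 gives 18.5%. Its nearest neighbour is compound 1 `CCCC(=O)Nc1cc(Oc2ccc(Nc3nccc4[nH]cc(-c5ccc(F)cc5)c(=O)c34)cc2F)ccn1`, which in this assay gives 23.5%, and the step of a number 5 percentage points lower from compound 1 to compound 2 (within the scatter) lies within the scatter. Compound 3 `Nc1nccc(Oc2ccc(Nc3nccc4[nH]cc(-c5ccc(F)cc5)c(=O)c34)cc2F)c1Cl` is not yet measured. It differs from compound 2 by 2-amino-3-chloropyridin-4-yl in place of 2-(((hydroxymethyl)carbonyl)amino)pyridin-4-yl on an oxygen on an aromatic ring. Among the compounds with values here, of the steps measured so far, only the step from compound 1 to compound 2 touches the group on that oxygen, and it was within the scatter; no measured step exchanges the whole 2-(((hydroxymethyl)carbonyl)amino)pyridin-4-yl group for 2-amino-3-chloropyridin-4-yl, so the change is not covered by the data. Compound 3 is therefore expected to stay near compound 2, with a step of a number 5.5 percentage points higher from compound 2 to compound 3 (within the scatter) that is not expected to exceed the scatter. The estimate for compound 3 in this assay is 24%, within a range from 5% to 50%.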

Compound 3, a percentage reported as inhibition, at one concentration (the size of the read-out at that concentration, not a potency): 56.2%
For compound 3 the middle estimate is 32.2 percentage points below the measured one; the whole stated range lies below it.
By their numbers in this assay, from the lowest: compounds 2 and 1 (each within the scatter of the next); then compound 3.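

In this assay the group on the oxygen on an aromatic ring turns out to be able to move the read-out by a large amount: 2-amino-3-chloropyridin-4-yl in place of 2-(((hydroxymethyl)carbonyl)amino)pyridin-4-yl gives the first step (a number 37.7 percentage points higher from compound 2 to compound 3 (beyond the scatter)), and in place of 2-((propylcarbonyl)amino)pyridin-4-yl it gives the second (a number 32.7 percentage points higher from compound 1 to compound 3 (beyond the scatter)). The earlier exchange on the saturated chain of the amide had stayed within the scatter (a number 5 percentage points lower from compound 1 to compound 2 (within the scatter)), so the large change appears only when the whole group is replaced. Nothing measured on these compounds bears on why this step is so large.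

The amino group and the chlorine enter together, so their shares in the step cannot be told apart. A 2-aminopyridin-4-yl group without chlorine, or a 2-acetamido-3-chloropyridin-4-yl group keeping both the amide and the chlorine, would be needed to separate them.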